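Swapping the Sulfonamide Aryl Phenyl for Methoxy

The compounds below may be only part of what the source reports. "The series", "measured", "known", "first", "only" and "open" are said of these compounds alone.

Compound 1, `Cc1ccc(NS(=O)(=O)c2ccc(Cl)cc2)cc1Nc1nccc(-c2cccnc2)n1`, in a functional assay on MCF7 cells (Homo sapiens) for cytotoxicity, read by MTT assay, with a stated time of 24 h (on this read-out higher numbers stand for weaker inhibition and lower numbers for stronger inhibition), gives 11800 nM.
Compound 2, `Cc1ccc(NS(=O)(=O)c2ccc(-c3ccccc3)cc2)cc1Nc1nccc(-c2cccnc2)n1`, in this assay gives 11900 nM.
Compound 3, `COc1cc(-c2ccnc(Nc3cc(NS(=O)(=O)c4ccc(-c5ccccc5)cc4)ccc3C)n2)cc(OC)c1OC`, in this assay gives 9330 nM.

Compound 3 carries the lowest of the three numbers, but its gaps to compound 1 and to compound 2 are both within the scatter, so the three measured compounds cannot be set in any order of strength. The two steps that connect them, a 1.0-fold higher number from compound 1 to compound 2 (0.00 log units; within the scatter) and a 1.3-fold lower number from compound 2 to compound 3 (0.11 log units; within the scatter), likewise stay within the scatter: neither exchange moved the read-out.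

Compound 4, `COc1ccc(S(=O)(=O)Nc2ccc(C)c(Nc3nccc(-c4cc(OC)c(OC)c(OC)c4)n3)c2)cc1`, differs from compound 3 in one place: methoxy in place of phenyl on an aromatic carbon. Among the measured compounds shown here, no measured step makes exactly this exchange. For the measured compounds named here, the closest precedent is a 1.0-fold higher number from compound 1 to compound 2 (0.00 log units; within the scatter), which also swapped one substituent on an aromatic carbon, chloro for phenyl, and left the number flat; the other change, a 1.3-fold lower number from compound 2 to compound 3 (0.11 log units; within the scatter), was equally flat. On that basis compound 4 is expected to show no step beyond the scatter in this assay, that is a 1.0-fold higher number from compound 3 to compound 4 (0.01 log units; within the scatter). The estimate for compound 4 is 9500 nM, with a range from 4500 nM to 20000 nM.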

Compound 4, half-maximal inhibitory concentration: 12300 nM
Beside the measured number, compound 4's estimate is 1.3-fold (0.11 log units) below it; measured number inside the range.
By their numbers in this assay, from the lowest: compounds 3, 1, 2 and 4 (each within the scatter of the next).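

In this assay, replacing phenyl with methoxy on an aromatic carbon of a six-membered aromatic ring of carbon only, para to a large group, gives a 1.3-fold higher number from compound 3 to compound 4 (0.12 log units; within the scatter). This exchange shortens the group far more than the earlier steps show: a whole six-membered aromatic ring of carbon only leaves and methoxy, with its hydrogen-bond acceptor, enters, yet the read-out does not move beyond the scatter, so the phenyl of compound 3 is not shown to be needed at this position in this assay. With the earlier 1.0-fold higher number from compound 1 to compound 2 (0.00 log units; within the scatter), chloro, phenyl and methoxy have now each taken part in a step at this position without any step beyond the scatter, although no information given here bears on why the number stays flat.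

As far as these compounds go, whether an amine, a carboxylic acid or a longer chain such as butoxy at this position would produce a step beyond the scatter remains open. Also open, from the compounds shown here alone, is whether the exchange of phenyl for methoxy would read the same with pyridin-3-yl in place of 3,4,5-trimethoxyphenyl.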